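Amide Substituent Variation in Rat Paw Edema Inhibition

The source may report more compounds than this note shows. Statements on the series, on what has been measured and on what is new or still open speak of the compounds shown alone.

Measured compounds:
compound 1 `COc1cc2c(cc1OC)C(CC(=O)N(C)C)CC2` — 36%
compound 2 `COc1cc2c(cc1OC)C(CC(=O)NC(C)(C)C)CC2` — 32%

In a functional assay on the whole organism (strain Wistar) for inhibition, with Rattus norvegicus as the target, read by paw edema, with stated times of 60 min and 2 h, at a dose of 100 mg/kg by the oral route (on this read-out higher numbers stand for more inhibition at the one dose given (going by the name of the read-out) and lower numbers for less inhibition), compound 1 gives 36% and compound 2 gives 32%. Within the data shown here, the one measured step, a number 4 percentage points lower from compound 1 to compound 2 (within the scatter), exchanges the group on the amide-type nitrogen and stays inside the scatter. On the numbers shown, compound 2 does not separate from compound 1; the two sit within the scatter of each other.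

Compound 3 `COc1cc2c(cc1OC)C(CC(=O)NC1CCCCC1)CC2` is the next compound, differing from compound 2 as cyclohexyl in place of tert-butyl on an amide-type nitrogen. The step from compound 1 to compound 2 bears on it only in that both vary the substituent on the amide-type nitrogen, and that step was small. Among the measured compounds shown here, no measured pair exchanges one carbon-only group for a larger one of this kind, so nothing points to a move beyond the scatter. The expected step of a number 1 percentage points higher from compound 2 to compound 3 (within the scatter) is therefore none beyond the scatter. Compound 3 is estimated at 33%, within a range of 20% to 46%.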

Compound 3, a percentage reported as inhibition, in the whole organism at one dose (the size of the read-out at that dose, not a potency): 56%
For compound 3 the middle estimate is 23 percentage points below the measured one; measured number above the stated range.
By their numbers in this assay, from the lowest: compounds 2 and 1 (each within the scatter of the next); then compound 3.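

Cyclohexyl in place of tert-butyl on the amide-type nitrogen gives a number 24 percentage points higher from compound 2 to compound 3 (beyond the scatter) in this assay, and cyclohexylamino in place of dimethylamino on the carbonyl carbon gives a number 20 percentage points higher from compound 1 to compound 3 (beyond the scatter). Among these compounds, this position can therefore move the read-out at the one dose given, which the exchange between compound 1 and compound 2 did not show, and among the three compounds only compound 3, the one with the cyclohexyl group, stands apart. Nothing at hand accounts for this difference.

The compounds shown leave open whether the difference belongs to the ring or to the carbon count of cyclohexyl, a question on which a hexyl chain or a cyclopentyl group on the same nitrogen would bear. Also open, as far as these compounds go, is how an amine or a carboxylic acid on the cyclohexyl ring would read out.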